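The source may report more compounds than this note shows. Statements on the series, on what has been measured and on what is new or still open speak of the compounds shown alone.

Measured compounds:
compound 1 `O=c1cc(O)c2ccc(OCc3cccc(Br)c3)cc2o1`, 0%
compound 2 `COCOc1cc(=O)oc2cc(OCc3cccc(Cl)c3)ccc12`, 23%

Both compounds were tested in an assay on isolated protein (strain Sprague-Dawley) for inhibition of Amine oxidase [flavin-containing] A (Rattus norvegicus), read by spectrophotometry, with a stated time of 5 min, tested at 10 uM; on this read-out lower numbers stand for less inhibition and higher numbers for more inhibition at the one concentration tested (going by the name of the read-out). Compound 1 gives 0%, and compound 2 gives 23%. Of the two numbers, compound 2 stands highest, and the gap to compound 1 is larger than the usual scatter of repeated measurements, so compound 2 is the one with measurable inhibition here. Among the compounds with values here, the two compounds differ in more than one place, so their two values show only that the pair behaves differently; no single change can be held responsible.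

Compound 3 `CCOC(=O)c1cc(=O)oc2cc(OCc3cccc(Cl)c3)ccc12` has not yet been measured in this assay. It differs from compound 2 in one place: ethoxycarbonyl in place of methoxymethoxy on an aromatic carbon. Within the data shown here, nothing measured so far tells how such a change acts in this assay, since only two compounds have numbers and neither pair isolates this change. The step from compound 2 is therefore expected to be small, a number 3 percentage points lower from compound 2 to compound 3 (within the scatter), and not beyond the scatter in either direction. On that basis compound 3 is estimated to give about 20% in this assay, with a range from 0% to 50%.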

Compound 3, a percentage reported as inhibition, at one concentration (the size of the read-out at that concentration, not a potency): 4.4%
Beside the measured number, compound 3's estimate is 15.6 percentage points above it; the range from low to high includes it.
By their numbers in this assay, from the lowest: compounds 1 and 3 (each within the scatter of the next); then compound 2.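

In this assay, within the data shown here, putting ethoxycarbonyl in place of methoxymethoxy on the aromatic carbon opposite the ring oxygen gives a number 18.6 percentage points lower from compound 2 to compound 3 (beyond the scatter) and is the first comparison here that isolates a single change, showing that the group at this position can shift the read-out. Both groups have 0 hydrogen-bond donors, 2 hydrogen-bond acceptors, no ring and no net charge, so these counts do not separate them, whereas ethoxycarbonyl has 5 heavy atoms against 4 and a double bond outside aromatic rings. No measurement on hand explains the size or direction of this step.

A single step cannot show which feature of the two groups matters, or whether the same swap would act alike with a different group on the rest of the core. Going by these compounds, how a carboxylic acid, an amide or a longer alkoxy chain at this position would read remains open, as does whether any group here can raise inhibition well beyond that of compound 2.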